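Ethoxy for Ethylsulfanyl: An Expected Step

The source may hold more compounds than are shown below. What is called first, only, known or untested is meant among the compounds shown, and "the series" means these compounds.

Measured so far in a functional assay (spleen, spleen) for activation, with Mus musculus as the target; on this read-out lower numbers stand for an effect already at smaller amounts and higher numbers for an effect only at larger amounts of compound:
Compound 1, `COc1cccc(Cn2c(O)nc3c(N)ncnc32)c1`: 10 uM
Compound 2, `CCSc1nc(N)c2nc(O)n(Cc3ccccc3)c2n1`: 0.1 uM
Compound 3, `Nc1ncnc2c1nc(I)n2Cc1ccccc1`: reported only as a limit of the assay, > 10 uM

Of the compounds shown here, three built on a shared core have been tested in this assay. Compound 2 stands lowest of the two numbers; the nearest number, that of compound 1, lies far higher, beyond the usual scatter of the assay. For compound 3 the assay gives no number, only (the limit of > 10 uM in this assay, at which 1 of the 3 values shown sits).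

Among the measured compounds shown here, no two of the measured compounds differ in a single place, so no measured step exists to lean on. Compound 4, `CCOc1nc(N)c2nc(O)n(Cc3ccccc3)c2n1`, has not yet been measured. It differs from compound 2 in one place: ethoxy in place of ethylsulfanyl on an aromatic carbon. Nothing measured here tells how this exchange alters the read-out, so the size of the step is a guess rather than a conclusion. It is expected to be small, pointing toward a somewhat higher number, and possibly within the scatter: a 3.0-fold higher number from compound 2 to compound 4 (0.48 log units; beyond the scatter). Compound 4 is therefore estimated at 0.3 uM, with a plausible range from 0.05 uM to 3 uM, and the measurement will show where it truly lands.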

Compound 4, minimum effective concentration: 0.1 uM
Compound 4: middle estimate off by 3.0-fold (0.48 log units), on the high side; measured number inside the range.
By their numbers in this assay, from the lowest: compounds 2 and 4 (each within the scatter of the next); then compound 1.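

Swapping ethylsulfanyl for ethoxy on this aromatic carbon, the one between two ring nitrogen atoms, gives no change at the digits printed from compound 2 to compound 4 (within the scatter) in this assay, and this is the first comparison here in which only one place differs. It shows that at this position, sulfur in the chain is not required for the effect to appear at this level, since the oxygen version, with the same count of heavy atoms, serves just as well on this read-out. This holds for this one pair on the shared core, and nothing available explains why the exchange leaves the number where it stands.

Compounds 1 and 3 differ from compound 2 and compound 4 in more than one place, so their steps cannot be read, and this single exchange does not show how much else the position would tolerate. Still open, from the compounds shown here alone, is whether a longer chain such as butoxy, or an amine such as butylamino, on the same carbon would keep the effect at these small amounts or lose it.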